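A Second Fluorine on the Ring of Compound 3

The source may report more compounds than this note shows. Statements on the series, on what has been measured and on what is new or still open speak of the compounds shown alone.

Compound 3 `CCCNc1cc(NC(=O)c2ccc(F)cc2)cc(C(F)(F)F)c1` gives 1400 nM in an assay on HEK293-TREx cells for antagonist activity at transient receptor potential cation channel subfamily A member 1 (Homo sapiens), read by calcium flux (on this read-out lower numbers stand for stronger inhibition and higher numbers for weaker inhibition), the highest of the two plain numbers here. Its nearest neighbour is compound 1 `CCCNc1cc(NC(=O)c2cccs2)cc(C(F)(F)F)c1`, which gives 390 nM; the step of a 3.6-fold higher number from compound 1 to compound 3 (0.56 log units; beyond the scatter) swaps the whole ring on the carbonyl carbon. Compound 2 `CCCNc1cc(NC(=O)c2ccccn2)cc(C(F)(F)F)c1` reaches only a limit of the assay, > 32000 nM. The steps of an at least 82-fold higher number from compound 1 to compound 2 (1.91 log units; beyond the scatter) and an at least 22-fold lower number from compound 2 to compound 3 (1.35 log units; beyond the scatter) likewise exchange the entire ring. Compound 4 `CCCNc1cc(NC(=O)c2ccc(F)c(F)c2)cc(C(F)(F)F)c1` differs from compound 3 only by fluoro in place of hydrogen on an aromatic carbon. Among the compounds with values here, none of the measured steps is a change of this kind, since each replaces the full ring rather than one substituent on it, so they give little guidance. The expected step of no change at the digits printed from compound 3 to compound 4 (within the scatter) is therefore none beyond the scatter. Compound 4 is estimated at 1400 nM, within 500 nM to 4000 nM.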

Compound 4, half-maximal inhibitory concentration: 1200 nM
Compound 4: the middle estimate sits 1.2-fold (0.07 log units) above what was measured, within the range that was stated.
By their numbers in this assay, from the lowest: compound 1; then compounds 4 and 3 (each within the scatter of the next). At a limit, above all of these: compound 2.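

In this assay, within the data shown here, this is the first step that alters one substituent on the ring rather than replacing the whole ring, and the step of a 1.2-fold lower number from compound 3 to compound 4 (0.07 log units; within the scatter) shows that fluoro at this place, ortho to a fluoro group, stays within the scatter. The thiophen-2-yl ring still gives the lower number, with the step of a 3.1-fold higher number from compound 1 to compound 4 (0.49 log units; beyond the scatter). The step of an at least 26-fold lower number from compound 2 to compound 4 (1.42 log units; beyond the scatter) starts from a limit of the assay, not a plain number.

On these data alone, whether a chlorine atom, a methoxy group or an amine at this place would also stay within the scatter remains open. So does whether other places on the ring would tolerate such groups.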